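The source may hold more compounds than are shown below. What is called first, only, known or untested is meant among the compounds shown, and "the series" means these compounds.

Working notes on the series. Compound 1 `COc1ccc(N2C(=O)NC3(CSC4=C3C(=O)c3ncccc3C4=O)C2=O)cc1` is the reference point. In a functional assay on ACHN cells (Homo sapiens) for antiproliferative activity, read by MTT assay, with a stated time of 96 h (on this read-out higher numbers stand for weaker inhibition and lower numbers for stronger inhibition), compound 1 gives 50 nM, the lowest of the two numbers recorded so far. Going by the values given here, the only other measured member, compound 2 `O=C1NN(c2ccc([N+](=O)[O-])cc2)C(=O)C2(CSC3=C2C(=O)c2ncccc2C3=O)N1`, carries a nitrophenyl on a differently built ring of the shared core; in this assay compound 2 gives 650 nM, a clearly higher number than compound 1, beyond the usual scatter. Among the compounds with values here, no single-point comparison between the measured compounds is available, so no measured step can be quoted.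

Compound 3 `O=C1C2=C(C(=O)c3ncccc31)C1(CS2)NC(=O)N(c2ccncc2)C1=O` has not yet been measured in this assay. It differs from compound 1 in one place: pyridin-4-yl in place of 4-methoxyphenyl on an amide-type nitrogen in a ring. The core and the ring arrangement are otherwise unchanged.

Within the data shown here, with no measured step of this kind to rest on, a modest loss is expected: the step of a 2.2-fold higher number from compound 1 to compound 3 (0.34 log units; beyond the scatter) is estimated to be small, at the edge of the scatter, in the direction of a higher number. For compound 3 the value in this assay is estimated at 110 nM, with a range from 40 nM to 350 nM.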

Compound 3, half-maximal inhibitory concentration: 80 nM
Compound 3: the middle estimate sits 1.4-fold (0.14 log units) above what was measured; low and high end bracket the measured number.
By their numbers in this assay, from the lowest: compounds 1 and 3 (each within the scatter of the next); then compound 2.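

In this assay, going by these compounds alone, pyridin-4-yl in place of 4-methoxyphenyl on the amide-type nitrogen gives a 1.6-fold higher number from compound 1 to compound 3 (0.20 log units; within the scatter), the first single-place step at this position, and the two values cannot be told apart. The position on the five-membered ring therefore accepts a six-membered aromatic ring with a ring nitrogen in place of the carbon-only ring carrying a methoxy group, with the value staying in the same range as that of compound 1. Nothing at hand bears on why the two groups read alike.

The compounds shown leave open whether this tolerance depends on where the ring nitrogen sits, as pyridin-2-yl or pyridin-3-yl would show, and whether the aromatic ring is needed at all, as a piperidine ring or a plain butyl chain on the same nitrogen would show. They also leave open how far the position tolerates a charged group, such as a carboxylic acid or a primary amine carried on the phenyl ring.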